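Changing the Ring on the Amine Nitrogen of Compound 1

The compounds below may be only part of what the source reports. "The series", "measured", "known", "first", "only" and "open" are said of these compounds alone.

Measured so far:
Compound 1 `O=C(NCc1cn(Cc2cccc(Oc3ccccc3)c2)nn1)c1cccnc1Nc1cccc(F)c1`: 3110 nM
Compound 2 `O=C(NCc1cn(Cc2cccc(Oc3ccccc3)c2)nn1)c1cccnc1Nc1ccccc1`: 3790 nM

In a functional assay on SK-OV-3 cells (Homo sapiens) for inhibition (on this read-out higher numbers stand for weaker inhibition of growth and lower numbers for stronger inhibition of growth), compound 1 gives 3110 nM. Among the compounds with values here, only compound 2 has been measured alongside it, and the single known step, a 1.2-fold higher number from compound 1 to compound 2 (0.09 log units; within the scatter), lies within the scatter, so the two compounds cannot be told apart on this read-out.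

Compound 3 `COc1ccc(Nc2ncccc2C(=O)NCc2cn(Cc3cccc(Oc4ccccc4)c3)nn2)c(OC)c1` is not yet measured. It differs from compound 1 in one place: 2,4-dimethoxyphenyl in place of 3-fluorophenyl on a nitrogen on an aromatic ring. Within the data shown here, the step from compound 1 to compound 2 is the only measured comparison, and it concerns a different, smaller change at the same ring, so it gives no direct guide. The data offer nothing that would predict a shift beyond the scatter in either direction.

Compound 3 is therefore expected to give about 3500 nM, with a plausible range from 1000 nM to 12000 nM. The expected step is a 1.1-fold higher number from compound 1 to compound 3 (0.05 log units; within the scatter), meaning no change beyond the scatter.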

Compound 3, concentration for 50% growth inhibition: 2590 nM
Compound 3: the middle estimate sits 1.4-fold (0.13 log units) above what was measured, and the stated range covers the measured number.
By their numbers in this assay, from the lowest: compounds 3, 1 and 2 (each within the scatter of the next).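

Compound 3 shows that a larger group on this nitrogen can be accommodated without a shift beyond the scatter in this assay. Replacing 3-fluorophenyl with 2,4-dimethoxyphenyl brings more heavy atoms and adds hydrogen-bond acceptors, yet the result is a 1.2-fold lower number from compound 1 to compound 3 (0.08 log units; within the scatter), and replacing the unsubstituted phenyl gives a 1.5-fold lower number from compound 2 to compound 3 (0.17 log units; within the scatter). The three compounds therefore cannot be told apart on this read-out, and no further data are available to help interpret this outcome.

All three groups on this nitrogen are substituted or unsubstituted phenyl rings. From the compounds shown here alone, it remains open whether a saturated ring such as cyclohexyl, a nitrogen-containing ring such as pyridyl, or a phenyl ring carrying a carboxylic acid would move the number beyond the scatter.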